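Adding a third methoxy to the ketone-side ring

The source may report more compounds than this note shows. Statements on the series, on what has been measured and on what is new or still open speak of the compounds shown alone.

Three compounds share one core. Compound 1 `COc1cc(-c2cc(/C=C/C(=O)c3ccc(Cl)c(Cl)c3)[nH]n2)cc(OC)c1OC` gives 3390 nM in a functional assay on LOX IMVI cells (Homo sapiens) for inhibition, read by sulforhodamine B assay, with a stated time of 48 h; a higher number here means a weaker inhibitor of growth, a lower number a stronger inhibitor of growth. Compound 2 `COc1ccc(C(=O)/C=C/c2cc(-c3cc(OC)c(OC)c(OC)c3)n[nH]2)cc1OC` gives 1380 nM, the lowest of the three numbers, and compound 3 `COc1ccc(C(=O)/C=C/c2cc(-c3cc(OC)c(OC)c(OC)c3)n[nH]2)cc1` gives 1580 nM. The change from compound 1 to compound 2, a 2.5-fold lower number from compound 1 to compound 2 (0.39 log units; beyond the scatter), is modest; the gap between compound 2 and compound 3, a 1.1-fold higher number from compound 2 to compound 3 (0.06 log units; within the scatter), is within the scatter. Compound 4 `COc1cc(C(=O)/C=C/c2cc(-c3cc(OC)c(OC)c(OC)c3)n[nH]2)cc(OC)c1OC` differs from compound 2 by methoxy in place of hydrogen on an aromatic carbon. The step from compound 2 to compound 3, which removed a methoxy from the same ring, stayed within the scatter, so adding one is expected to do likewise: the expected step is a 1.0-fold higher number from compound 2 to compound 4 (0.01 log units; within the scatter). Compound 4 is therefore estimated at 1400 nM, between 700 nM and 2800 nM.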

Compound 4, concentration for 50% growth inhibition: 1520 nM
Compound 4: middle estimate off by 1.1-fold (0.04 log units), on the low side; the measured number falls inside the stated range.
By their numbers in this assay, from the lowest: compounds 2, 4 and 3 (each within the scatter of the next); then compound 1.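

In this assay, the extra methoxy gives a 1.1-fold higher number from compound 2 to compound 4 (0.04 log units; within the scatter). Compound 3 showed that taking a methoxy off this ring left the number within the scatter, and compound 4 shows the same for adding one, on an aromatic carbon ortho to a methoxy group. Across these three compounds, the number of methoxy groups on this ring makes no readable difference, and nothing shown gives a reason for this. Still open, on these data alone, is whether an amine, a carboxylic acid or a longer alkoxy chain at this position would also leave the number within the scatter.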